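The source may report more compounds than this note shows. Statements on the series, on what has been measured and on what is new or still open speak of the compounds shown alone.

The account concerns three compounds measured in a physicochemical assay for lipophilicity, read by HPLC, at pH 7.5 (a lower number here means a more polar compound, a higher number a more lipophilic compound), and a fourth not yet measured there. Compound 1, `CC[C@@H](Nc1c(C#N)c(-c2ccc(-c3ccccc3NC)cc2)nc2cnccc12)C(N)=O`, gives 2.5 in this assay. Compound 2, `CCOc1ccccc1-c1ccc(-c2nc3cnccc3c(N[C@H](CC(C)C)C(N)=O)c2C#N)cc1`, gives 3.4. Compound 3, `CC[C@@H](Nc1c(C#N)c(-c2ccc(-c3cccc(C)c3F)cc2)nc2cnccc12)C(=O)O`, gives 2.1. Among these three numbers compound 1 stands second highest: compound 3 lies below it by a margin beyond the usual scatter, and compound 2 lies above it by a wider margin, also beyond the scatter. Within the data shown here, no pair of these three compounds differs in a single place, so no step between measured compounds can be read off directly.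

Compound 4, `CC[C@@H](Nc1c(C#N)c(-c2ccc(Br)cc2)nc2cnccc12)C(N)=O`, is the unmeasured compound and differs from compound 1 in one place: bromo in place of 2-(methylamino)phenyl on an aromatic carbon. The group that leaves carries a six-membered aromatic ring and one hydrogen-bond donor and acceptor, while the group that enters is a single bromine with neither. Among the measured compounds shown here, no measured step of this kind is available, so the expectation rests on the change alone. The step from compound 1 to compound 4 is expected to be a number 0.60 log units lower from compound 1 to compound 4 (beyond the scatter), a decrease beyond the scatter. Compound 4 is therefore estimated at 1.9, with a range from 1.3 to 2.5.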

Compound 4, distribution coefficient: 2.2
Estimate against measurement, compound 4: 0.30 log units below; low and high end bracket the measured number.
By their numbers in this assay, from the lowest: compounds 3, 4 and 1 (each within the scatter of the next, the first and the last beyond it); then compound 2.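

In this assay, among these compounds, the exchange at this position, bromo in place of 2-(methylamino)phenyl on an aromatic carbon para to a large group, gives a number 0.30 log units lower from compound 1 to compound 4 (within the scatter) and is the first single-place step that can be read. The earlier compounds shown here could not show this, since no two of them differ in one place only. The change is a large one in structure, for the group that leaves has 8 heavy atoms, a six-membered aromatic ring of carbon only, a hydrogen-bond donor and a hydrogen-bond acceptor, while the group that enters is a single bromine, yet the two compounds stand within the usual scatter of each other, and nothing at hand explains this closeness.

The compounds shown leave open whether other groups at this place, such as chloro, an unsubstituted phenyl or a phenyl carrying a primary amine, would also stay within the scatter of compound 1. They also leave open whether the same exchange would give a similar step on a compound carrying the carboxylic acid of compound 3 or the longer chain of compound 2.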